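Aryl urea series: trifluoromethyl in place of tert-butyl

The compounds below may be only part of what the source reports. "The series", "measured", "known", "first", "only" and "open" are said of these compounds alone.

Measured so far:
compound 1 `Cc1ccc(NC(=O)Nc2cccc(CNc3nccnc3Cl)c2)cc1` — 11500 nM in a functional assay on HepG2 cells (Homo sapiens) for antiproliferative activity, read by MTT assay, with a stated time of 48 h; a lower number here means a stronger inhibitor, a higher number a weaker inhibitor
compound 2 `O=C(Nc1ccccc1)Nc1cccc(CNc2nccnc2Cl)c1` — 15600 nM in this assay
compound 3 `CC(C)(C)c1ccc(NC(=O)Nc2cccc(CNc3nccnc3Cl)c2)cc1` — 7550 nM in this assay

Compound 3 gives the lowest number of the three, but its gap to compound 1 is within the scatter a 1.5-fold lower number from compound 1 to compound 3 (0.18 log units; within the scatter); only against compound 2 does it stand apart a 2.1-fold lower number from compound 2 to compound 3 (0.32 log units; beyond the scatter). The whole series moves little: a 1.4-fold higher number from compound 1 to compound 2 (0.13 log units; within the scatter).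

Compound 4 `O=C(Nc1ccc(C(F)(F)F)cc1)Nc1cccc(CNc2nccnc2Cl)c1` differs from compound 3 in one place:
trifluoromethyl in place of tert-butyl on an aromatic carbon
All three measured steps at this position are small, so in this assay a step at most near the edge of the scatter is expected for compound 4, if anything toward a higher number: a 1.3-fold higher number from compound 3 to compound 4 (0.10 log units; within the scatter). Compound 4 is estimated at 9500 nM, range 4500 nM to 20000 nM.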

Compound 4, half-maximal inhibitory concentration: 5050 nM
For compound 4 the middle estimate is 1.9-fold (0.27 log units) above the measured one; the measured number falls inside the stated range.
By their numbers in this assay, from the lowest: compounds 4, 3, 1 and 2 (each within the scatter of the next, the first and the last beyond it).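

In this assay, trifluoromethyl at this position cannot be separated from tert-butyl (a 1.5-fold lower number from compound 3 to compound 4 (0.17 log units; within the scatter)), yet it stands apart from both hydrogen (a 3.1-fold lower number from compound 2 to compound 4 (0.49 log units; beyond the scatter)) and methyl (a 2.3-fold lower number from compound 1 to compound 4 (0.36 log units; beyond the scatter)). Compound 4 is thus the only compound shown whose steps from both compound 1 and compound 2 lie beyond the scatter, although these steps remain modest. No measured evidence on hand bears on these steps.

As far as these compounds go, whether an amine, a carboxylic acid or a methoxy group at this position would give a larger step remains open. So does whether the trifluoromethyl step would persist with changes elsewhere on the shared core.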